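This account rests on a few compounds, and the source may have more. Where it says the series, first, only, none or still open, it means among the compounds named here.

Compound 1 `COc1cc(-c2nc3ccc([N+](=O)[O-])cc3[nH]2)cc(-c2nc3ccc([N+](=O)[O-])cc3[nH]2)c1` and compound 2 `O=[N+]([O-])c1cc(-c2nc3ccc([N+](=O)[O-])cc3[nH]2)cc(-c2nc3ccc([N+](=O)[O-])cc3[nH]2)c1` share one core and differ only in that compound 2 carries nitro in place of methoxy on an aromatic carbon. In an ADME assay on L02 cells (Homo sapiens) for cytotoxicity, read by MTT assay, with a stated time of 48 h (a lower number here means a stronger inhibitor, a higher number a weaker inhibitor), compound 1 gives 26300 nM, while compound 2 gives 44900 nM, so that a 1.7-fold higher number from compound 1 to compound 2 (0.23 log units; within the scatter). Compound 3 `COc1cc(-c2nc3ccc(C(F)(F)F)cc3[nH]2)cc(-c2nc3ccc(C(F)(F)F)cc3[nH]2)c1` is built on a different core; how that core differs from the core of compound 1 is not broken down here. In this assay compound 3 gives 10100 nM, the lowest of the three numbers, with both other compounds standing beyond the scatter from it.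

Compound 4 `O=[N+]([O-])c1cc(-c2nc3ccc(C(F)(F)F)cc3[nH]2)cc(-c2nc3ccc(C(F)(F)F)cc3[nH]2)c1` has not been measured in this assay. It differs from compound 3 by nitro in place of methoxy on an aromatic carbon, the same change that separates compound 2 from compound 1, at the same place. Since the earlier step lay within the scatter, the step is expected to be a 1.6-fold higher number from compound 3 to compound 4 (0.20 log units; within the scatter), a small rise at most. Compound 4 is therefore estimated to give 16000 nM in this assay, with a likely range from 7000 nM to 40000 nM, resting on a single earlier example of the change.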

Compound 4, half-maximal inhibitory concentration: 3700 nM
Compound 4: middle estimate off by 4.3-fold (0.64 log units), on the high side; measured number outside the range, below it.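

In this assay, nitro in place of methoxy on an aromatic carbon gives a 2.7-fold lower number from compound 3 to compound 4 (0.44 log units; beyond the scatter), a modest fall in the number on this core, whereas the same change on the core of compound 1 stayed within the scatter. Set side by side, the two steps do not agree, so the result of this change could not be carried from one core to the other in this series: the same change on two cores in this assay, a 1.7-fold higher number (0.23 log units; within the scatter) from compound 1 to compound 2 and a 2.7-fold lower number (0.44 log units; beyond the scatter) from compound 3 to compound 4, 4.7-fold (0.67 log units) apart, beyond the scatter of two such steps

Within the data shown here, this shows that the step depends on the core in these two pairs, but with only two pairs it does not show which feature of the cores is responsible, nor does it give a rule for any further core.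

The compounds shown leave open how an amine, a carboxylic acid or a longer chain such as ethoxy would behave at the place held by methoxy and nitro. They also leave open what the same change would do on a core that carries chlorine instead of nitro or trifluoromethyl.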